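Ring substituents on the core of compound 1 and paw edema

A few compounds are considered here, and "the series" means these few. Any claim that something is new, unique, unknown or untested is made for them only; others in the source may bear on it.

Compound 1 `CCOC(=O)C(=O)Nc1cccccc1=O` is the reference point of the series. For the measured compounds named here, in a functional assay on the whole organism (strain Sprague-Dawley CD) for inhibition, with Rattus norvegicus as the target, read by paw edema, at a dose of 30 mg/kg by the intraperitoneal route (on this read-out lower numbers stand for a weaker effect and higher numbers for a stronger effect at the one dose given), compound 1 gives 84%, the highest of the three numbers measured so far; compound 3 `CCOC(=O)C(=O)Nc1ccccc(C)c1=O` at 60% is nearest, and compound 2 `CCOC(=O)C(=O)Nc1c(Oc2ccccc2)ccccc1=O` at 0% is furthest. Both measured steps put a group in place of a hydrogen on an aromatic carbon of the shared core: a number 24 percentage points lower from compound 1 to compound 3 (beyond the scatter) is a modest loss, whereas a number 84 percentage points lower from compound 1 to compound 2 (beyond the scatter) is a large one that removes the effect entirely.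

Compound 4 `CCOC(=O)C(=O)Nc1cccc(OC)cc1=O` has not yet been measured. It differs from compound 1 by methoxy in place of hydrogen on an aromatic carbon. Both measured steps bear on it, since each also replaces a ring hydrogen; the entering group is intermediate in size between methyl and phenoxy. A fall beyond the scatter in this assay is therefore expected, of a size between those two steps. For compound 4 the expected step is a number 39 percentage points lower from compound 1 to compound 4 (beyond the scatter). The estimate for compound 4 in this assay is 45%, with a range from 10% to 75%.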

Compound 4, a percentage reported as inhibition, in the whole organism at one dose (the size of the read-out at that dose, not a potency): 67%
Beside the measured number, compound 4's estimate is 22 percentage points below it, and the stated range covers the measured number.
By their numbers in this assay, from the lowest: compound 2; then compounds 3 and 4 (each within the scatter of the next); then compound 1.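

Methoxy on this carbon of the seven-membered aromatic ring, three ring bonds from the ring atom that bears the group of 8 heavy atoms, costs only part of the effect in this assay: a number 17 percentage points lower from compound 1 to compound 4 (beyond the scatter) is a modest step, and compound 4 remains clearly active at the one dose given. Thus a group attached through oxygen does not by itself abolish the read-out, although compound 2 goes against any broader reading, with a number 84 percentage points lower from compound 1 to compound 2 (beyond the scatter), and there group and ring carbon both differ from compound 4, so the two steps cannot separate these changes. No evidence on the cause of the step from compound 1 to compound 4 is available.

Open, as far as these compounds go, is how an amine, a hydroxyl or a longer chain such as ethoxy would fare on this same carbon. Also open, from the compounds shown here alone, is whether methoxy would keep the effect on the ring carbon that bears phenoxy in compound 2.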